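Methyl in Place of Hydrogen on the Phenyl of Compound 1

The source may hold more compounds than are shown below. What is called first, only, known or untested is meant among the compounds shown, and "the series" means these compounds.

Measured compounds:
compound 1 `c1ccc(C(C2Cc3ccccc3O2)n2cnnn2)cc1` — 35%
compound 2 `O=[N+]([O-])c1ccc2c(c1)CC(C(c1ccccc1)n1cnnn1)O2` — 14.4%

Among the measured compounds shown here, in an assay for inhibition of Aromatase (Homo sapiens), tested at 20 uM (a higher number here means more inhibition at the concentration tested (going by the name of the read-out), a lower number less inhibition), compound 1 gives 35%, the higher of the two numbers measured so far. Compound 2 `O=[N+]([O-])c1ccc2c(c1)CC(C(c1ccccc1)n1cnnn1)O2` carries a nitro in place of hydrogen on an aromatic carbon, and in this assay compound 2 gives 14.4%; the step of a number 20.6 percentage points lower from compound 1 to compound 2 (beyond the scatter) is modest but beyond the scatter.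

Compound 3 `Cc1ccc(C(C2Cc3ccccc3O2)n2cnnn2)cc1` is not yet measured. It differs from compound 1 by methyl in place of hydrogen on an aromatic carbon. For the measured compounds named here, only one measured step exists, and it concerns a nitro on a different aromatic carbon, so it bears on this change only loosely. The expectation is therefore a step from compound 1 to compound 3 of no clear size or direction, estimated as no change at the digits printed from compound 1 to compound 3 (within the scatter). For compound 3 the value expected in this assay is 35%, with a range from 15% to 55%.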

Compound 3, a percentage reported as inhibition, at one concentration (the size of the read-out at that concentration, not a potency): 67.2%
Estimate against measurement, compound 3: 32.2 percentage points below, outside the stated range (above it).
By their numbers in this assay, from the lowest: compound 2; then compound 1; then compound 3.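

In this assay, methyl in place of hydrogen on the phenyl gives a number 32.2 percentage points higher from compound 1 to compound 3 (beyond the scatter), a large step and the first upward one in this series. Among the compounds shown here, it shows that this aromatic carbon, para to a large group, is a place where a single added carbon raises the inhibition read at the tested concentration, whereas the only earlier step, a number 20.6 percentage points lower from compound 1 to compound 2 (beyond the scatter), concerned a nitro on a different aromatic carbon and went the other way. No measurement at hand gives a reason for this rise.

The compounds shown leave open whether the gain is particular to methyl or extends to a longer chain such as ethyl, or to a methoxy, a chlorine or an amine on the same carbon. They also leave open what methyl would do on the aromatic carbon that carries the nitro in compound 2.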